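Replacing Benzyl with 4-Hydroxycyclohexyl on an Aromatic Oxygen

The compounds below may be only part of what the source reports. "The series", "measured", "known", "first", "only" and "open" are said of these compounds alone.

Compound 2 `O=[N+]([O-])c1ccc(NC(=S)NCCNS(=O)(=O)c2ccc(-c3ccccc3OCc3ccccc3)s2)cc1` was tested in a functional assay on HL-60 cells (Homo sapiens) for inhibition, read by CCK-8 assay, with a stated time of 48 h; on this read-out lower numbers stand for stronger inhibition and higher numbers for weaker inhibition. Compound 2 sits at a limit of the assay, > 50000 nM, and this is not a measured number. Compound 3 `O=[N+]([O-])c1cccc(NC(=S)NCCNS(=O)(=O)c2ccc(-c3ccccc3OCc3ccccc3)s2)c1` also sits at a limit, > 50000 nM. Among the compounds with values here, the only measured step among the close relatives, a step that the two limits leave unreadable from compound 2 to compound 3, gives no size to work with, and it concerns the nitrophenyl group rather than the group changed here.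

Compound 4 `O=[N+]([O-])c1ccc(NC(=S)NCCNS(=O)(=O)c2ccc(-c3ccccc3O[C@H]3CC[C@H](O)CC3)s2)cc1` departs from compound 2 in one place: 4-hydroxycyclohexyl in place of benzyl on an oxygen on an aromatic ring. In plain words, 4-hydroxycyclohexyl takes the place of benzyl on an oxygen on an aromatic ring. Within the data shown here, no measured step isolates this swap, so the best guide is compound 1 `O=C(NCCNS(=O)(=O)c1ccc(-c2ccccc2O[C@H]2CC[C@H](O)CC2)s1)Nc1ccc([N+](=O)[O-])cc1`, which carries the same 4-hydroxycyclohexyl group on that oxygen. In this assay compound 1 gives a real number, 8900 nM.

On the strength of compound 1 at 8900 nM, a move towards stronger inhibition, meaning a lower number, is expected. The estimated step is an at least 4.1-fold lower number from compound 2 to compound 4 (0.61 log units; beyond the scatter), and its size stays uncertain since its starting point is only a limit. The estimate for compound 4 is 12000 nM, with an expected range from 4000 nM to 50000 nM.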

Compound 4, half-maximal inhibitory concentration: 11600 nM
Compound 4: the middle estimate sits 1.0-fold (0.01 log units) above what was measured; low and high end bracket the measured number.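

In this assay, the change of benzyl to 4-hydroxycyclohexyl on an oxygen on an aromatic ring now has a readable effect, with the two compounds otherwise the same: an at least 4.3-fold lower number from compound 2 to compound 4 (0.63 log units; beyond the scatter). With 4-hydroxycyclohexyl in place, exchanging an oxygen for sulfur in the group on an amine nitrogen leaves no readable difference, as the step is a 1.3-fold higher number from compound 1 to compound 4 (0.12 log units; within the scatter). The full size of the first step remains unknown because compound 2 gives only a limit and not a number: the limit of > 50000 nM in this assay, at which 2 of the 4 values shown sit.

This single swap removes an aromatic ring and adds a hydroxyl group at once, so a plain cyclohexyl or a 4-aminocyclohexyl group on the same oxygen would be needed to show which part of the change matters. On these data alone, the step between the 4-nitrophenyl and 3-nitrophenyl compounds cannot be read, so it remains open whether the placement of the nitro group matters, and that question could be tested with 4-hydroxycyclohexyl on the oxygen, where the values are real numbers.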